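Swapping methoxy for methylamino at the assay limit

This account rests on a few compounds, and the source may have more. Where it says the series, first, only, none or still open, it means among the compounds named here.

Compound 3 `CCCCCCC(CCO)n1cnc2c(OC)ncnc21` gives only a limit in a functional assay on SW480 cells (Homo sapiens) for antiproliferative activity, read by MTT assay, with a stated time of 48 h (a higher number here means a weaker inhibitor, a lower number a stronger inhibitor), namely > 50000 nM. Compound 2 `CCCCCCC(CCO)n1cnc2c(Cl)ncnc21`, which carries chloro on the same aromatic carbon, gives a true number, 16700 nM. Among the measured compounds shown here, that swap of chloro for methoxy is the one measured step that touches this carbon, an at least 2.9-fold higher number from compound 2 to compound 3 (0.47 log units; beyond the scatter), and since it ends in a limit, its full size stays unknown. For the measured compounds named here, the series so far shows (the limit of > 50000 nM in this assay, at which 2 of the 3 values shown sit).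

Compound 4 `CCCCCCC(CCO)n1cnc2c(NC)ncnc21` has methylamino in place of the methoxy of compound 3 on an aromatic carbon of a six-membered aromatic ring with 2 nitrogen, part of a fused or bridged system of two rings, opposite the ring nitrogen: methylamino in place of methoxy on an aromatic carbon. Going by the values given here, no measured step shows this exact exchange. The nearest hint comes from compound 1 `CCCCCC(CCO)n1cnc2c(NC)ncnc21`, which also carries methylamino and gives only a limit, > 50000 nM, so no clear gain is expected for compound 4. No step beyond the scatter is therefore expected in this assay, in either direction. The expected move is an at least 1.1-fold lower number from compound 3 to compound 4 (0.04 log units; that floor lies within the scatter). Compound 4 is estimated at 45000 nM, with an expected range from 18000 nM to 100000 nM, and it may well return only a limit.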

Compound 4, half-maximal inhibitory concentration: > 50000 nM
Compound 4: a limit, no number (the forecaster's own chance of this, stated with the estimate: 70%); at least 1.1-fold (0.04 log units) between middle value and limit.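

Compound 4 gives only a limit in this assay, > 50000 nM. Methylamino in place of chloro on this aromatic carbon gives an at least 2.9-fold higher number from compound 2 to compound 4 (0.47 log units; beyond the scatter), so two different replacements for chloro, methoxy and methylamino, both leave the measurable range, and among the compounds shown only chloro at this carbon gives a true number. The steps from compound 3 to compound 4 and from compound 1 to compound 4 cannot be read, with limits at both ends, and the series now stands as follows: the limit of > 50000 nM in this assay, at which 3 of the 4 values shown sit.

On these data alone, how far compound 1, compound 3 and compound 4 lie past that limit stays unknown, so methoxy and methylamino cannot be ranked against each other, and the methyl that separates the chains of compound 1 and compound 4 has no visible effect of a readable size. As far as these compounds go, it also remains open whether another group on this carbon, such as bromo or dimethylamino, would give a true number as chloro does, and whether a longer chain would change the picture.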